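This account rests on a few compounds, and the source may have more. Where it says the series, first, only, none or still open, it means among the compounds named here.

Measured compounds in a toxicity assay on THP-1 cells (Homo sapiens) for inhibition; on this read-out lower numbers stand for higher toxicity in this test and higher numbers for lower toxicity in this test:
Compound 1 `Cn1c(-c2ccccc2)cnc1NC(=O)c1ncc[nH]1` gives > 100000 nM, a limit of the assay.
Compound 2 `COc1cccc(-c2cnc(NC(=O)c3ncc[nH]3)n2C)c1` gives > 100000 nM, likewise a limit.
Compound 3 `Cn1c(-c2ccccc2Cl)cnc1NC(=O)c1ncc[nH]1` gives > 50000 nM, also a limit.

Compound 1 thus stands at the limit of > 100000 nM in this assay, at which 2 of the 3 values shown sit, and no number sits below either limit. Compound 4 `Cn1c(-c2ccccc2)cnc1NC(=O)c1ccc(Br)cc1` is not yet measured; it differs from compound 1 by 4-bromophenyl in place of 1H-imidazol-2-yl on a carbonyl carbon. Going by the values given here, the only measured steps, a step that the two limits leave unreadable from compound 1 to compound 2 and a step that the two limits leave unreadable from compound 1 to compound 3, change a different part of the molecule and their sizes cannot be read, so nothing here tells how exchanging the group on the carbonyl carbon shifts this read-out. With all three known values at the limit of > 100000 nM in this assay, at which 2 of the 3 values shown sit, or (the limit of > 50000 nM in this assay, at which 1 of the 3 values shown sits), compound 4 is expected to stay near that region, and its estimated step of an at least 1.2-fold lower number from compound 1 to compound 4 (0.09 log units; that floor lies within the scatter) is no larger than the scatter. Compound 4 is therefore estimated at 80000 nM, within 20000 nM to 200000 nM.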

Compound 4, half-maximal cytotoxic concentration: > 100000 nM
Compound 4 was reported as a limit (the forecaster's own chance of this, stated with the estimate: 60%); at least 1.2-fold (0.09 log units) between middle value and limit.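

Compound 1 and compound 4 are both reported only as limits in this assay, so the step between them cannot be read. The compounds shown leave open whether exchanging the group on the carbonyl carbon shifts this read-out at all.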